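This account rests on a few compounds, and the source may have more. Where it says the series, first, only, none or still open, it means among the compounds named here.

Measured compounds:
Compound 1, `Cc1nnsc1CO/N=C/c1c(C)nn(C)c1Oc1ccc(OC(F)(F)F)cc1`: 12800 nM
Compound 2, `CCc1nnsc1CO/N=C/c1c(C)nn(C)c1Oc1ccc(OC(F)(F)F)cc1`: 12500 nM
Compound 3, `Cc1nnsc1CO/N=C/c1c(C)nn(C)c1Cl`: > 50000 nM (a limit of the assay, not a number)

In a functional assay on HCT-116 cells (Homo sapiens) for inhibition, read by MTT assay, with a stated time of 48 h (on this read-out higher numbers stand for weaker inhibition and lower numbers for stronger inhibition), compound 1 gives 12800 nM and compound 2 gives 12500 nM. Among the compounds with values here, the single change between them is methyl in place of hydrogen on a saturated chain carbon bound to an aromatic carbon, and the step is a 1.0-fold lower number from compound 1 to compound 2 (0.01 log units; within the scatter). Compound 3 reaches only the limit of this assay, > 50000 nM. The difference between the core of compound 3 and the core of compound 1 is not broken down here. Compound 4, `CCc1nnsc1CO/N=C/c1c(C)nn(C)c1Cl`, carries the same change on the core of compound 3: methyl in place of hydrogen on a saturated chain carbon bound to an aromatic carbon. The expected step is a step that the limit leaves unreadable from compound 3 to compound 4, because the same change gave a 1.0-fold lower number from compound 1 to compound 2 (0.01 log units; within the scatter). Compound 4 is therefore expected to stay at the limit of > 50000 nM in this assay, at which 1 of the 3 values shown sits, with an estimate of 70000 nM and a likely range from 30000 nM to 200000 nM.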

Compound 4, half-maximal inhibitory concentration: > 50000 nM
Compound 4: no number, only a limit; the forecaster's own chance of this, stated with the estimate: 85%; the middle value does not contradict the limit.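

Compound 3 and compound 4 both give a limit of the assay rather than a number, and the step between them cannot be read: the limit of > 50000 nM in this assay, at which 2 of the 4 values shown sit. The compounds shown leave open whether methyl in place of hydrogen changes inhibition at all on the core of compound 3.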